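This account rests on a few compounds, and the source may have more. Where it says the series, first, only, none or still open, it means among the compounds named here.

Measured so far in an assay (Cavia porcellus) for inhibition of Polyunsaturated fatty acid 5-lipoxygenase (Homo sapiens); a lower number here means a stronger inhibitor, a higher number a weaker inhibitor:
compound 1 `CN(O)C(=O)C1=Cc2ccccc2OC1` gives 830 nM
compound 2 `NC(=O)N(O)CC1=Cc2cc(OCc3ccccc3)ccc2OC1` gives 440 nM
compound 3 `NC(=S)N(O)CC1=Cc2cc(Oc3ccccc3)ccc2OC1` gives 180 nM

Compound 3 holds the lowest number of the three; compound 2 sits above it by a gap beyond the scatter, and compound 1 further still. Compound 4 `C=CCNC(=O)N(O)CC1=Cc2cc(Oc3ccccc3)ccc2OC1` differs from compound 3 in one place: a group of 6 heavy atoms (4 carbon, 1 nitrogen, 1 oxygen; no ring) in place of a group of 3 heavy atoms (1 carbon, 1 nitrogen, 1 sulfur; no ring), on an amine nitrogen. Among the compounds with values here, no pair of measured compounds differs in one place only, so there is no single-change step to set the size of this change. In this assay the step is expected to be small, more likely towards a higher number than a lower one, and it may not reach beyond the scatter. For compound 4 the estimate is 300 nM, within a range from 120 nM to 800 nM, which means an expected step of a 1.7-fold higher number from compound 3 to compound 4 (0.22 log units; within the scatter).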

Compound 4, half-maximal inhibitory concentration: 37 nM
Compound 4: the middle estimate sits 8.1-fold (0.91 log units) above what was measured; the whole stated range lies above it.
By their numbers in this assay, from the lowest: compound 4; then compound 3; then compounds 2 and 1 (each within the scatter of the next).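

In this assay, allylcarbamoyl in place of the group of 3 heavy atoms on this amine nitrogen gives a 4.9-fold lower number from compound 3 to compound 4 (0.69 log units; beyond the scatter) as a step beyond the scatter, so the position responds to what it carries and accepts the larger group. The change brings in oxygen for sulfur and adds the allyl part at once, so the step cannot be divided between them. No measurement shown accounts for the step.

Open, going by these compounds, is whether allylthiocarbamoyl, propylcarbamoyl or a longer chain on this nitrogen would hold the number near that of compound 4. Also open, on these data alone, is whether the same group keeps this step on a core with benzyloxy in place of phenoxy.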